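The compounds below may be only part of what the source reports. "The series", "measured", "known", "first", "only" and "open" are said of these compounds alone.

Measured so far:
Compound 1, `Cc1c(Br)sc(N)c1C(=O)c1ccc(Cl)cc1`: 1%
Compound 2, `CC(C)(C)Cc1c(-c2ccccn2)sc(N)c1C(=O)c1ccc(Cl)cc1`: 1%
Compound 3, `COc1ccc(-c2sc(N)c(C(=O)c3ccc(Cl)c(Cl)c3)c2CC(C)(C)C)cc1`: 1%

All three share a core and were tested in an assay on CHO cells for displacement of a labelled ligand from adenosine receptor A3 (Homo sapiens), read by scintillation counting, tested at 10 uM; on this read-out lower numbers stand for less inhibition and higher numbers for more inhibition at the one concentration tested (going by the name of the read-out). In this assay compound 2 gives 1%, level with compound 1 and compound 3 at the digits shown, with no change beyond the usual scatter toward either of them. Compound 4, `CC(C)(C)Cc1c(-c2ccsc2)sc(N)c1C(=O)c1ccc(Cl)cc1`, has not yet been measured. It differs from compound 2 in one place: thiophen-3-yl in place of pyridin-2-yl on an aromatic carbon. Among the measured compounds shown here, no step between measured compounds exists here, so there is no measured size to build on; since every measured compound sits at the same low level, the change is expected to bring no step beyond the scatter. Compound 4 is therefore expected to give 2% in this assay, with a range from 0% to 12%. The step estimated for compound 4 is a number 1 percentage points higher from compound 2 to compound 4 (within the scatter).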

Compound 4, a percentage reported as inhibition, at one concentration (the size of the read-out at that concentration, not a potency): 4%
The estimate for compound 4 lay 2 percentage points below the measured number, within the range that was stated.
By their numbers in this assay, from the lowest: compounds 1, 2, 3 and 4 (each within the scatter of the next).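

In this assay, among the compounds shown here, thiophen-3-yl in place of pyridin-2-yl on this aromatic carbon gives a number 3 percentage points higher from compound 2 to compound 4 (within the scatter) and is the first change in a single place that can be read. At this low level, a five-membered aromatic ring with sulfur and a six-membered aromatic ring with nitrogen can therefore stand in for each other here with no change beyond the scatter. No measurement at hand offers an explanation for this result.

Going by these compounds, whether an amine, a carboxylic acid or a longer chain at this place would move the number beyond the scatter stays open. Also open, on these data alone, is whether a change elsewhere on the shared core would do so.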